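The compounds below may be only part of what the source reports. "The series", "measured", "known", "first", "only" and "open" are said of these compounds alone.

Working notes on the series. In a functional assay on K562-TAX cells (Homo sapiens), read by MTT assay, with a stated time of 3 days (a higher number here means a weaker inhibitor, a lower number a stronger inhibitor), compound 1 `CNc1ncnc2[nH]cc(Sc3cccs3)c12` gives 21000 nM. Compound 2 `Nc1ncnc2[nH]cc(Sc3cccs3)c12` gives 17900 nM in this assay, and compound 3 `c1csc(Sc2c[nH]c3ncnc(-c4cccs4)c23)c1` gives 21700 nM. Compound 3 has the highest of these three numbers, but all three lie within the scatter of each other, so it holds no distinct rank.

The next comparison is with compound 4 `c1coc(-c2ncnc3[nH]cc(Sc4cccs4)c23)c1`, which differs from compound 3 as follows: furan-2-yl in place of thiophen-2-yl on an aromatic carbon. In words, this is furan-2-yl in place of thiophen-2-yl on an aromatic carbon.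

For the measured compounds named here, three measured steps bear on this place in the structure. Replacing the substituent there gave a 1.0-fold higher number from compound 1 to compound 3 (0.01 log units; within the scatter) and a 1.2-fold higher number from compound 2 to compound 3 (0.08 log units; within the scatter), and the change on the nitrogen of that substituent gave a 1.2-fold lower number from compound 1 to compound 2 (0.07 log units; within the scatter). All three are small and within the scatter. Going by the values given here, none of them tests furan-2-yl, and no measured compound carries that group, so the evidence is indirect.

In this assay, no step beyond the scatter is therefore expected, in either direction. The expected step is a 1.1-fold lower number from compound 3 to compound 4 (0.04 log units; within the scatter). For compound 4 the estimated value is 20000 nM, with an expected range from 11000 nM to 38000 nM.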

Compound 4, half-maximal inhibitory concentration: 18900 nM
The estimate for compound 4 lay 1.1-fold (0.02 log units) above the measured number; the measured number falls inside the stated range.
By their numbers in this assay, from the lowest: compounds 2, 4, 1 and 3 (each within the scatter of the next).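

In this assay, for the compounds shown here, furan-2-yl in place of thiophen-2-yl gives a 1.1-fold lower number from compound 3 to compound 4 (0.06 log units; within the scatter), the first exchange at this aromatic carbon between two five-membered aromatic rings with one hetero atom each, and sulfur against oxygen in that ring leaves the number within the scatter. Against the smaller nitrogen substituents at the same place, furan-2-yl also stays within the scatter, with a 1.1-fold higher number from compound 2 to compound 4 (0.02 log units; within the scatter) and a 1.1-fold lower number from compound 1 to compound 4 (0.05 log units; within the scatter), so amino, methylamino, thiophen-2-yl and furan-2-yl do not separate from one another in these four compounds. Nothing at hand gives a reason for this flat response at this place.

Going by these compounds, whether any group at this aromatic carbon can move the number beyond the scatter remains open, for example a carboxylic acid, a phenyl ring or a longer chain on the amine. All four compounds also share the rest of the core, including its sulfur-linked thiophene, so what that part contributes to the numbers in this assay cannot be read from this set.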